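Adding a Second Chlorine to a Purine Benzyl Series

The source may report more compounds than this note shows. Statements on the series, on what has been measured and on what is new or still open speak of the compounds shown alone.

Of the compounds shown here, three sharing one core have been tested in a functional assay on TK-10 cells (Homo sapiens) for cytotoxicity, read by sulforhodamine B assay, with a stated time of 48 h; a higher number here means a weaker inhibitor of growth, a lower number a stronger inhibitor of growth. Compound 3, `ClCc1cccc(Cn2cnc3ncnc(Cl)c32)c1`, gives 3310 nM, the lowest number of the three. Compound 1, `ClCc1ccc(Cn2cnc3c(Cl)ncnc32)cc1`, gives 4670 nM, a number so close to that of compound 3 that the two cannot be told apart by this measurement. Compound 2, `ClCc1ccccc1Cn1cnc2c(Cl)ncnc21`, gives 46800 nM, clearly higher than the number of compound 3, so compound 2 is the weaker inhibitor of growth among these three.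

Compound 4, `ClCc1cccc(Cn2cnc3nc(Cl)nc(Cl)c32)c1`, is the next structure. It differs from compound 3 by chloro in place of hydrogen on an aromatic carbon, that is, a chloro group entering on an aromatic carbon of a six-membered aromatic ring with 2 nitrogen, between two ring nitrogen atoms. For the measured compounds named here, no measured pair shows this exact change, so there is no direct guide to its size. A small step, staying within the usual scatter, is expected in this assay, as the addition is a single heavy atom. The expected step from compound 3 to compound 4 is a 1.1-fold lower number from compound 3 to compound 4 (0.04 log units; within the scatter). For compound 4 the estimate is 3000 nM, with a range from 800 nM to 12000 nM.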

Compound 4, concentration for total growth inhibition: 30200 nM
Compound 4: middle estimate off by 10-fold (1.00 log units), on the low side; measured number above the stated range.
By their numbers in this assay, from the lowest: compounds 3 and 1 (each within the scatter of the next); then compounds 4 and 2 (each within the scatter of the next).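

In this assay, placing one chloro group on the aromatic carbon between two ring nitrogen atoms gives a 9.1-fold higher number from compound 3 to compound 4 (0.96 log units; beyond the scatter), a step beyond the scatter. For the compounds shown here, compounds 1, 2 and 3 all carry hydrogen on this carbon, so only this step shows that the position is sensitive to change, with a single added heavy atom clearly weakening growth inhibition. No measurement shown here accounts for this loss.

Going by these compounds, it remains open whether any replacement for hydrogen on this carbon has a similar effect, or whether the step is specific to chloro; a fluoro, a methyl or an amine there would help to separate these possibilities. Also unknown is whether the same addition would produce a step of similar size in compound 1 or compound 2.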